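Swapping a Branched Chain for a Plain Ring

This account rests on a few compounds, and the source may have more. Where it says the series, first, only, none or still open, it means among the compounds named here.

Measured compounds:
compound 1 `Cc1cc(O)c(CC(O)C(C)CC[C@H]2[C@@H](C)CCCC2(C)C)c(O)c1C=O` — 2120 nM
compound 2 `C=C(CC/C=C(\C)CCC=C(C)C)C(O)Cc1c(O)cc(C)c(C=O)c1O` — 7530 nM

Both were tested in a functional assay on EC17 cells (Homo sapiens) for inhibition, with a stated time of 24 h; on this read-out lower numbers stand for stronger inhibition and higher numbers for weaker inhibition. Of the two, compound 2 gives the higher number, and its distance from compound 1 lies beyond the usual scatter. Compound 3 `C=C(CCC1CCCCC1)C(O)Cc1c(O)cc(C)c(C=O)c1O` is not yet measured. It differs from compound 2 in one place: cyclohexyl in place of 2,6-dimethylhepta-1,5-dien-1-yl on a saturated chain carbon, two bonds along the chain from a double-bonded chain carbon. Among the measured compounds shown here, with no measured pair showing this exact change, only a modest step is expected, more likely toward lower numbers than higher, since the one ring-bearing compound measured, compound 1, gives 2120 nM. The step of a 1.5-fold lower number from compound 2 to compound 3 (0.18 log units; within the scatter) is therefore expected to be small. Compound 3 is expected to give 5000 nM, within 2000 nM to 12000 nM.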

Compound 3, half-maximal inhibitory concentration: 8430 nM
Estimate against measurement, compound 3: 1.7-fold (0.23 log units) below; measured number inside the range.
By their numbers in this assay, from the lowest: compound 1; then compounds 2 and 3 (each within the scatter of the next).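

In this assay, cyclohexyl in place of 2,6-dimethylhepta-1,5-dien-1-yl gives a 1.1-fold higher number from compound 2 to compound 3 (0.05 log units; within the scatter) and so leaves the read-out effectively unchanged. For this one pair, the open chain and its two double bonds are not needed to keep the number where it stands, and a six-membered carbon ring serves equally well. No supporting measurement explains this result. Still open, from the compounds shown here alone, is whether a phenyl ring, an amine or a carboxylic acid at this position would move the number beyond the scatter. A single pair also cannot show whether the same swap behaves alike on other side chains.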